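This account rests on a few compounds, and the source may have more. Where it says the series, first, only, none or still open, it means among the compounds named here.

The study concerns three compounds measured in a physicochemical assay for lipophilicity, read by HPLC (a higher number here means a more lipophilic compound, a lower number a more polar compound), and one that still awaits its number. Compound 2 `CC(=O)NC[C@H]1CN(c2ccc(OC[C@H](O)CNc3ccccc3)c(F)c2)C(=O)O1` is the most polar of the measured set: in this assay compound 2 gives 0.59. Compound 1 `COc1ccc(NC[C@@H](O)COc2ccc(N3C[C@H](CNC(C)=O)OC3=O)cc2F)cc1` differs from it in one place, (methoxy in place of hydrogen on an aromatic carbon), and in this assay compound 1 gives 1.15, so that this change produced a number 0.56 log units higher from compound 2 to compound 1 (beyond the scatter). Compound 3 `CC(=O)NC[C@H]1CN(c2ccc(OC[C@@H]3CN(c4ccccc4)C(=O)O3)c(F)c2)C(=O)O1` is built on a different core, and the difference between the core of compound 3 and the core of compound 2 is not broken down here. In this assay compound 3 gives 1.78, the highest of the three numbers, standing beyond the scatter above both compound 1 and compound 2.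

Compound 4 `COc1ccc(N2C[C@@H](COc3ccc(N4C[C@H](CNC(C)=O)OC4=O)cc3F)OC2=O)cc1` has not yet been measured. It differs from compound 3 by methoxy in place of hydrogen on an aromatic carbon. This is the same change that separates compound 2 from compound 1, made at the same kind of place, on an aromatic carbon of a six-membered aromatic ring of carbon only, para to a large group. The step from compound 3 to compound 4 in this assay is expected to be a number 0.47 log units higher from compound 3 to compound 4 (beyond the scatter), because the same change gave a number 0.56 log units higher from compound 2 to compound 1 (beyond the scatter). Compound 4 is accordingly estimated at 2.25. For compound 4 the expected range runs from 1.85 to 2.65.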

Compound 4, partition coefficient: 1.91
For compound 4 the middle estimate is 0.34 log units above the measured one; low and high end bracket the measured number.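

In this assay, methoxy in place of hydrogen on an aromatic carbon gave a number 0.56 log units higher from compound 2 to compound 1 (beyond the scatter) on one core, whereas on the core of compound 3 the same change, phenyl to 4-methoxyphenyl, gave a number 0.13 log units higher from compound 3 to compound 4 (within the scatter) and so did not reproduce a step beyond the scatter. This shows that, for these two pairs, the step seen on the first core could not be carried over in size to the second, even though the change was made at the same kind of place, para to a large group. It does not show a rule for the series, as each core is represented by a single pair, and nothing at hand accounts for the two steps reading differently.

The compounds shown leave open how an amine, a carboxylic acid or a longer chain such as ethoxy, set in that same place, would read on either core in this assay. They also leave open whether methoxy on any further core would give a step like the one on the core of compound 2 or the one on the core of compound 3.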